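A few compounds are considered here, and "the series" means these few. Any claim that something is new, unique, unknown or untested is made for them only; others in the source may bear on it.

In an ADME assay on microsomes from liver (Mus musculus) for metabolic stability, read by LC-MS (on this read-out higher numbers stand for a longer-lived compound and lower numbers for a shorter-lived compound), three compounds that share one core and differ only in a fluorinated phenyl group have been measured. Compound 1 `O=C(Nc1ccc(F)c(-c2nc3ncc(-c4ccc(F)cc4)cc3[nH]2)c1)N1CCCC1` gives 0.095 h, compound 2 `O=C(Nc1ccc(F)c(-c2nc3ncc(-c4cccc(F)c4)cc3[nH]2)c1)N1CCCC1` gives 0.0833 h and compound 3 `O=C(Nc1ccc(F)c(-c2nc3ncc(-c4cc(F)cc(F)c4)cc3[nH]2)c1)N1CCCC1` gives 0.128 h, so compound 3 stands level with the other two once the usual scatter is allowed for. Compound 4 `O=C(Nc1ccc(F)c(-c2nc3ncc(-c4ccccc4F)cc3[nH]2)c1)N1CCCC1` carries 2-fluorophenyl in place of the 3,5-difluorophenyl of compound 3 on an aromatic carbon (2-fluorophenyl in place of 3,5-difluorophenyl on an aromatic carbon). Among the compounds with values here, three measured steps bear on this change. Replacing 4-fluorophenyl with 3-fluorophenyl gave a 1.1-fold lower number from compound 1 to compound 2 (0.06 log units; within the scatter), replacing it with 3,5-difluorophenyl gave a 1.3-fold higher number from compound 1 to compound 3 (0.13 log units; within the scatter), and placing fluoro on an aromatic carbon in place of hydrogen gave a 1.5-fold higher number from compound 2 to compound 3 (0.19 log units; within the scatter). Within the data shown here, none of the measured compounds carries 2-fluorophenyl, so this exact group remains untested. Going by steps as small as a 1.5-fold higher number from compound 2 to compound 3 (0.19 log units; within the scatter), no step beyond the scatter is expected in this assay. The expected change is a 1.3-fold lower number from compound 3 to compound 4 (0.11 log units; within the scatter). For compound 4 the estimated half-life is 0.1 h, with an expected range of 0.055 h to 0.18 h.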

Compound 4, half-life: 0.172 h
Compound 4: middle estimate off by 1.7-fold (0.24 log units), on the low side; the range from low to high includes it.
By their numbers in this assay, from the lowest: compounds 2, 1, 3 and 4 (each within the scatter of the next, the first and the last beyond it).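

In this assay, within the data shown here, the place of a lone fluorine on this phenyl group can shift the half-life: 2-fluorophenyl in place of 3-fluorophenyl gives a 2.1-fold higher number from compound 2 to compound 4 (0.31 log units; beyond the scatter) and is the only modest step in this set that clears the scatter. Putting 2-fluorophenyl in place of 4-fluorophenyl gives a 1.8-fold higher number from compound 1 to compound 4 (0.26 log units; within the scatter) and so does not clear it. Swapping 3,5-difluorophenyl for 2-fluorophenyl, which removes one fluorine, gives a 1.3-fold higher number from compound 3 to compound 4 (0.13 log units; within the scatter) and shows that a second fluorine is not needed to hold the half-life at this level. Nothing measured here explains why the fluorine's place matters. Also open is whether 2-chlorophenyl or 2-methoxyphenyl would behave like 2-fluorophenyl, and where an unsubstituted phenyl would fall among these four.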